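A few compounds are considered here, and "the series" means these few. Any claim that something is new, unique, unknown or untested is made for them only; others in the source may bear on it.

Measured so far in a functional assay on HEK293 cells for agonist activity at Bombesin receptor subtype-3 (Mus musculus), read by luminescence and calcium flux, with a stated time of 10 min; on this read-out higher numbers stand for an effect only at larger amounts of compound and lower numbers for an effect already at smaller amounts:
Compound 1 `CCC(C)(C)Cc1c[nH]c(CCc2ccc(-n3ccnn3)cc2)n1` — 111 nM
Compound 2 `CCC(C)(C)Cc1c[nH]c(CCc2ccc(-c3cccc(N)n3)cc2)n1` — 119 nM
Compound 3 `c1ccc(-c2ccc(CCc3nc(CC4CCCC4)c[nH]3)cc2)nc1` — 103 nM

Compound 2 carries the highest number of the three, but compound 1, its nearest neighbour, and compound 3, its furthest, both lie within the scatter of it, so the three measured compounds cannot be told apart on this assay. Among the measured compounds shown here, the only single-point step is a 1.1-fold higher number from compound 1 to compound 2 (0.03 log units; within the scatter), which shows that exchanging one aromatic group on that carbon for another left the read-out where it was. Compound 4 `CCC(C)(C)Cc1c[nH]c(CCc2ccc(-c3ccns3)cc2)n1` carries the next exchange at the same place: 1,2-thiazol-5-yl in place of 6-aminopyridin-2-yl on an aromatic carbon. For the measured compounds named here, the step from compound 1 to compound 2 is the only measured step that bears on this, and it stayed within the scatter; a step of no more than that size, that is none beyond the scatter, is therefore expected, a 1.0-fold higher number from compound 2 to compound 4 (0.00 log units; within the scatter). For compound 4 the number expected on this assay is 120 nM, with a range from 50 nM to 300 nM.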

Compound 4, half-maximal effective concentration: 103 nM
Estimate against measurement, compound 4: 1.2-fold (0.07 log units) above; the measured number falls inside the stated range.
By their numbers in this assay, from the lowest: compounds 3, 4, 1 and 2 (each within the scatter of the next).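

Working notes on the aromatic carbon para to a large group: on this assay, the 1,2-thiazol-5-yl group gives a step within the scatter against 6-aminopyridin-2-yl (a 1.2-fold lower number from compound 2 to compound 4 (0.06 log units; within the scatter)) and against 1H-1,2,3-triazol-1-yl (a 1.1-fold lower number from compound 1 to compound 4 (0.03 log units; within the scatter)). This adds a five-membered aromatic ring carrying sulfur to the groups that cannot be told apart here, and compound 2, compound 1 and compound 4 now form a closed set of three exchanges at one place, all within the scatter. No measurement bears on why these groups cannot be told apart.

All three groups at this place are aromatic rings, so the compounds shown leave open what a morpholine ring, a carboxylic acid or a plain methyl would give there. Any group that moves the read-out beyond the scatter at this place also remains to be identified.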